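The source may hold more compounds than are shown below. What is called first, only, known or untested is meant among the compounds shown, and "the series" means these compounds.

Measured so far:
compound 1, `CN(Cc1ccccc1)S(=O)(=O)c1ccc(NC(=O)NCc2ccncc2)cc1` — 23 nM
compound 2, `CCOC(=O)c1ccc(N(C)C(=O)NCc2ccncc2)cc1` — > 100000 nM
compound 3, `CCOC(=O)c1ccc(NC(=O)NCc2cc[nH]n2)cc1` — 69000 nM

The read-out throughout is an assay on isolated protein for activation of Nicotinamide phosphoribosyltransferase (Homo sapiens); on this read-out higher numbers stand for an effect only at larger amounts of compound and lower numbers for an effect already at smaller amounts. On this read-out compound 1 gives 23 nM, the lowest number of the two that were obtained. Compound 3, which carries an ethyl ester in place of the sulfonamide and a pyrazolylmethyl group on the urea, gives 69000 nM, a far higher number, well beyond the scatter. For the measured compounds named here, compound 2 reaches no number at all in this assay: its value of > 100000 nM is a limit of the assay, and it is the one value sitting at the limit of > 100000 nM in this assay, at which 1 of the 3 values shown sits. Going by the values given here, no pair of these three compounds differs in one place only, so no single step can be read from them.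

The compound still to be measured is compound 4, `O=C(NCc1ccncc1)Nc1ccc(S(=O)(=O)c2ccc(Cl)cc2)cc1`. It keeps the core of compound 1, with the urea and the pyridylmethyl group intact, and differs from it in one place: 4-chlorophenyl in place of benzyl(methyl)amino on a sulfonyl sulfur. Among the compounds with values here, nothing among the measured compounds tests this exchange, so the size of the step is open. The author expects compound 4 to stay in the same general region as compound 1, with a step from compound 1 to compound 4 of a 3.5-fold higher number from compound 1 to compound 4 (0.54 log units; beyond the scatter) toward a somewhat higher number, though it could also fall within the scatter. Accordingly compound 4 is estimated at 80 nM in this assay, between 15 nM and 500 nM.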

Compound 4, half-maximal effective concentration: 126 nM
For compound 4 the middle estimate is 1.6-fold (0.20 log units) below the measured one; the range from low to high includes it.
By their numbers in this assay, from the lowest: compound 1; then compound 4; then compound 3. At a limit, above all of these: compound 2.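

For the compounds shown here, putting 4-chlorophenyl in place of benzyl(methyl)amino on a sulfonyl sulfur gives a 5.5-fold higher number from compound 1 to compound 4 (0.74 log units; beyond the scatter) in this assay and shows, for the first time, what a change at this position costs. The cost is limited: the sulfonyl sulfur can carry an aromatic ring in place of the benzyl(methyl)amino group, and with the rest of the core of compound 1 unchanged, compound 4 still gives 126 nM on this read-out. Nothing in the information available bears on why the step has this size.

A plain phenyl or a 4-fluorophenyl on the sulfonyl sulfur would show whether the chlorine contributes to the value of compound 4, and a benzylamino or dimethylamino group there would show which part of benzyl(methyl)amino goes with the lower number of compound 1. Steps involving compound 2 or compound 3 cannot be read, as each differs from the other compounds in more than one place.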